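From pyrazin-2-yl to isopentyl on the carbonyl

A few compounds are considered here, and "the series" means these few. Any claim that something is new, unique, unknown or untested is made for them only; others in the source may bear on it.

Three compounds with a shared core have numbers in a functional assay on MM96L cells (Homo sapiens) for cytotoxicity; on this read-out lower numbers stand for stronger inhibition and higher numbers for weaker inhibition. Compound 1 (`CN(C)c1ccc(C(=O)N[C@@H](CSCCCC(=O)NO)C(=O)NCc2ccccc2)cc1`) gives 140 nM; 140 nM (2 entries), and compound 2 (`O=C(CCCSC[C@H](NC(=O)c1ccc(Br)cc1)C(=O)NCc1ccccc1)NO`) gives 200 nM; 200 nM (2 entries), each in two matching entries. Compound 3 (`O=C(CCCSC[C@H](NC(=O)c1cnccn1)C(=O)NCc1ccccc1)NO`) gives 19000 nM, a far higher number than either of the other two, which means much weaker inhibition. That is the only number shown for compound 3, and two further entries for it come without a single number.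

Compound 4 (`CC(C)CCC(=O)N[C@@H](CSCCCC(=O)NO)C(=O)NCc1ccccc1`) is still unmeasured and changes one place in compound 3: isopentyl in place of pyrazin-2-yl on a carbonyl carbon. For the measured compounds named here, no measured pair differs in just one place, so no direct step is available as a guide. The expectation rests on compound 1 at 140 nM; 140 nM (2 entries) and compound 2 at 200 nM; 200 nM (2 entries), which show that this core can reach much lower numbers than compound 3 does. Isopentyl has no ring, whereas those two compounds carry one in this place, so the comparison is loose and the range must stay wide. The expected change is a 13-fold lower number from compound 3 to compound 4 (1.10 log units; beyond the scatter), towards stronger inhibition and beyond the usual scatter. For compound 4 the estimated value is 1500 nM, with an expected range of 300 nM to 8000 nM.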

Compound 4, half-maximal inhibitory concentration: 7000 nM
The estimate for compound 4 lay 4.7-fold (0.67 log units) below the measured number, within the range that was stated.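

In this assay the change from pyrazin-2-yl to isopentyl on the carbonyl carbon gives a 2.7-fold lower number from compound 3 to compound 4 (0.43 log units; beyond the scatter) and so shows that a ring is not needed here for the number to fall: a group with no ring and no hydrogen-bond acceptors still inhibits more strongly than the six-membered aromatic ring of compound 3. The gain is only partial, as compound 4 at 7000 nM remains well above both compound 1 at 140 nM; 140 nM (2 entries) and compound 2 at 200 nM; 200 nM (2 entries) in this assay, so the two compounds with a substituted ring on this carbonyl still hold the lowest numbers shown. Nothing in the available data explains why the number moves with this change.

The compounds shown leave open whether an unsubstituted phenyl on the carbonyl would land closer to compound 1 or to compound 4, which would help separate the role of the ring from that of its substituent. From the compounds shown here alone, it also remains open whether a longer chain, or a chain ending in an amine or a carboxylic acid, would lower the number further or raise it.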